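Cytotoxicity series: methyl in place of methoxy

The source may hold more compounds than are shown below. What is called first, only, known or untested is meant among the compounds shown, and "the series" means these compounds.

Measured compounds:
compound 1 `CCOc1ccc(NC(=O)c2cccc(/C=C3\CC(=O)N(Cc4ccccc4)C3=O)c2)cc1`, 41700 nM
compound 3 `CCCCCN1C(=O)C/C(=C\c2cccc(C(=O)Nc3cccc(CC)c3)c2)C1=O`, 75300 nM
compound 2 `COc1ccc(NC(=O)c2cccc(/C=C3\CC(=O)N(c4ccccc4)C3=O)c2)cc1`, a limit only: > 100000 nM

In an ADME assay on HCT-116 cells (Homo sapiens) for cytotoxicity, read by MTT assay, with a stated time of 72 h (a lower number here means a stronger inhibitor, a higher number a weaker inhibitor), compound 1 gives 41700 nM and compound 3 gives 75300 nM. Compound 2 reaches only the assay limit, > 100000 nM. On the numbers shown compound 2 stands at the limit of > 100000 nM in this assay, at which 1 of the 3 values shown sits. Compound 4 `Cc1ccc(NC(=O)c2cccc(/C=C3\CC(=O)N(c4ccccc4)C3=O)c2)cc1` is not yet measured; it differs from compound 2 by methyl in place of methoxy on an aromatic carbon. Among the measured compounds shown here, no measured pair differs in a single place, so nothing here sets the size of this step. The expected step is a number no higher from compound 2 to compound 4 (the limit leaves the size open), none beyond the scatter, given that compound 2 rests at the limit of > 100000 nM in this assay, at which 1 of the 3 values shown sits. Compound 4 is expected near the limit, at 100000 nM, within 40000 nM to 250000 nM.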

Compound 4, half-maximal inhibitory concentration: > 100000 nM
Compound 4 ended at the assay's limit; the forecaster's own chance of this, stated with the estimate: 60%; the middle value sits exactly at the limit.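

In this assay compound 2 gives > 100000 nM, a limit. Among the compounds shown here, compound 4 gives > 100000 nM, also a limit, so no step between compound 2 and compound 4 can be read. Going by these compounds, the size of the change from methoxy to methyl on an aromatic carbon stays open.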